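The source may report more compounds than this note shows. Statements on the series, on what has been measured and on what is new or still open speak of the compounds shown alone.

In an in vitro functional assay on SH-SY5Y cells for agonist activity at Neuronal acetylcholine receptor; alpha3/beta4 (Homo sapiens), read by FLIPR and calcium flux (on this read-out lower numbers stand for smaller maximal responses and higher numbers for larger maximal responses), compound 3 `C1=C(c2cccnc2)C[C@H]2CNC[C@@H]1C2` gives 142%, a number that the scatter does not separate from compound 2 `Clc1ccc(C2=CC3CNCC(C2)C3)cn1` at 141%, whereas compound 1 `CN1C[C@H]2C=C(c3cccnc3)C[C@H](C2)C1` gives 31%, far below both. The only measured step among these three is a number 111 percentage points higher from compound 1 to compound 3 (beyond the scatter), a change at the amine nitrogen rather than in configuration. Compound 4 `C1=C(c2cccnc2)C[C@@H]2CNC[C@H]1C2` is the mirror image of compound 3: the two compounds have the same atoms and bonds and differ only in configuration as drawn: 2 of 2 stereo elements differ (all stereocentres are inverted: mirror images); a stereocentre at a saturated ring carbon is drawn S in compound 3 and R in compound 4; a stereocentre at a saturated ring carbon is drawn R in compound 3 and S in compound 4. For the measured compounds named here, no measured step inverts a stereocentre, so nothing here shows how large such a move can be or in which direction it runs, and the estimate must stay wide. The step is expected as a number 42 percentage points lower from compound 3 to compound 4 (beyond the scatter). Compound 4 is therefore expected to reach 100% in this assay, within a range from 30% to 150%.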

Compound 4, largest response reached (reported as percent of maximum), in percent of the reference or control that the assay uses: 139%
The estimate for compound 4 lay 39 percentage points below the measured number; the measured number falls inside the stated range.
By their numbers in this assay, from the lowest: compound 1; then compounds 4, 2 and 3 (each within the scatter of the next).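

In this assay, inverting both stereocentres gives a number 3 percentage points lower from compound 3 to compound 4 (within the scatter), so this read-out does not separate the two mirror images. The earlier compounds shown here showed a large step only at the amine nitrogen, whereas this pair shows that the configuration at these two saturated ring carbons can change with the response staying within the scatter. Nothing else varies in this pair: the fact that compounds 3 and 4 differ only in the configuration as drawn.

The compounds shown leave open whether the mirror image of compound 1 would behave in the same way. They also leave open how an ethyl group or a longer chain on the amine nitrogen would affect the response.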